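The source may report more compounds than this note shows. Statements on the series, on what has been measured and on what is new or still open speak of the compounds shown alone.

Measured so far:
compound 1 `CCC(CC)(CC(=O)Nc1cccc(OCc2ccc3cc(F)ccc3n2)c1)C(=O)O`, a functional assay on ileum (Cavia porcellus) for antagonist activity at cysteinyl leukotriene receptor (Homo sapiens); on this read-out lower numbers stand for stronger inhibition and higher numbers for weaker inhibition: 2 nM
compound 2 `CCC(CC)(CC(=O)Nc1cccc(OCc2ccc3ccccc3n2)c1)C(=O)O`, this assay: 0.9 nM

Compound 2 gives the lowest number of the two; the step of a 2.2-fold lower number from compound 1 to compound 2 (0.35 log units; beyond the scatter) separates it from compound 1. Compound 3 `CCC(CC)(CC(=O)Nc1cccc(OCc2ccc3ccc(C(C)=O)cc3n2)c1)C(=O)O` has not been measured. It differs from compound 2 by acetyl in place of hydrogen on an aromatic carbon. For the measured compounds named here, only one measured step exists, and it concerns fluoro against hydrogen, not acetyl, so it bears on this change only loosely. A small step, probably toward a higher number, is expected for compound 3, a 2.2-fold higher number from compound 2 to compound 3 (0.35 log units; beyond the scatter), with considerable uncertainty. The expected value for compound 3 in this assay is 2 nM, within the range 0.6 nM to 7 nM.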

Compound 3, half-maximal inhibitory concentration: 2500 nM
For compound 3 the middle estimate is 1300-fold (3.10 log units) below the measured one; the whole stated range lies below it.
By their numbers in this assay, from the lowest: compound 2; then compound 1; then compound 3.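

In this assay, placing acetyl in place of hydrogen on this aromatic carbon gives a 2800-fold higher number from compound 2 to compound 3 (3.44 log units; beyond the scatter). For the compounds shown here, this shows that one small change at this position can cost far more inhibition than the only earlier step, fluoro against hydrogen, suggested. Nothing available explains why this change has so large an effect. As far as these compounds go, whether the loss belongs to acetyl itself or would follow any group other than hydrogen on this carbon remains open. A methyl, a hydroxyl or an amine at the same place would help to separate those possibilities.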